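Replacing a bromine with a trifluoroethoxy group on compound 3

The source may report more compounds than this note shows. Statements on the series, on what has been measured and on what is new or still open speak of the compounds shown alone.

The measured compounds and their values:
Compound 1, `CCCOC(=O)c1c(C)coc1-c1ccc2c(CC)cccc2c1OC`, gives a limit of the assay, > 10 ug/mL.
Compound 2, `CCc1cccc2c(OC)c(-c3occ(C)c3C(=S)OC)ccc12`, gives 5.7 ug/mL.
Compound 3, `CCc1cccc2c(OC)c(-c3occ(C)c3CBr)ccc12`, gives a limit of the assay, > 10 ug/mL.

In a functional assay on DU-145 cells (Homo sapiens) for cytotoxicity, read by MTT assay, with a stated time of 72 h (a lower number here means that less compound is needed, a higher number that more compound is needed for the effect), compound 3 stands only at a limit, > 10 ug/mL, not at a number. Two of the three values shown sit at this same limit (the limit of > 10 ug/mL in this assay, at which 2 of the 3 values shown sit), so compound 3 cannot be placed more exactly than that. Compound 4, `CCc1cccc2c(OC)c(-c3occ(C)c3COCC(F)(F)F)ccc12`, differs from compound 3 in one place: 2,2,2-trifluoroethoxy in place of bromo on a saturated chain carbon bound to an aromatic carbon. Two measured steps lead into compound 3. The change from compound 2 to compound 3 gave an at least 1.7-fold higher number from compound 2 to compound 3 (0.24 log units; that floor lies within the scatter), and the change from compound 1 to compound 3 gave a step that the two limits leave unreadable from compound 1 to compound 3. Among the compounds with values here, neither step involves a group like the one entering compound 4, and the limit on compound 3 itself makes any step from it hard to read. The expected step from compound 3 to compound 4 is therefore small, a step that the limit leaves unreadable from compound 3 to compound 4, with the value most likely again ending at the limit. Compound 4 is estimated at 12 ug/mL, within a range from 4 ug/mL to 40 ug/mL.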

Compound 4, concentration for half-maximal effect: 5.7 ug/mL
Beside the measured number, compound 4's estimate is 2.1-fold (0.32 log units) above it; measured number inside the range.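

In this assay, replacing the bromo of compound 3 with 2,2,2-trifluoroethoxy, on a saturated chain carbon bound to an aromatic carbon, gives an at least 1.7-fold lower number from compound 3 to compound 4 (0.24 log units; that floor lies within the scatter). Compound 3 stands at > 10 ug/mL, which is a limit of the assay, so the true size of this step cannot be read: the limit of > 10 ug/mL in this assay, at which 2 of the 4 values shown sit. The two further comparisons read no change at the digits printed from compound 2 to compound 4 (within the scatter) and an at least 1.7-fold lower number from compound 1 to compound 4 (0.24 log units; that floor lies within the scatter), so among the compounds shown, a readable number at this place no longer depends on the sulfur-bearing group of compound 2, since a group without sulfur now gives one too.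

A plain ethoxy group or an amine on the same chain carbon would help separate the part played by the fluorine atoms from that of the oxygen, and the compounds shown leave this open. Within the data shown here, they also leave open whether a change at this place can give a step clearly beyond the usual scatter, as no step here has a floor that clears it.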